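Methyl removal on the alkyl chain, tested across two pairs

The source may hold more compounds than are shown below. What is called first, only, known or untested is meant among the compounds shown, and "the series" means these compounds.

Working notes on four compounds sharing one core. Compound 1 `CCC(C)(C)/N=c1\c(O)c(O)\c1=N/Cc1ccc(F)cc1Cl` and compound 2 `CCC(C)(C)/N=c1\c(O)c(O)\c1=N/Cc1c(Cl)cccc1Cl` both carry a 1,1-dimethylpropyl group on a double-bonded nitrogen; the difference between the two cores is not broken down here. In a functional assay for inhibition, with Rattus norvegicus as the target (on this read-out higher numbers stand for weaker inhibition and lower numbers for stronger inhibition), compound 1 gives 1500 nM, and compound 2 gives 280 nM.

Compound 3 `CC(C)(C)/N=c1\c(O)c(O)\c1=N/Cc1c(Cl)cccc1Cl` is compound 2 after one change: hydrogen in place of methyl on a saturated chain carbon, two bonds along the chain from a double-bonded nitrogen. In this assay compound 3 gives 1100 nM, which is a 3.9-fold higher number from compound 2 to compound 3 (0.59 log units; beyond the scatter). Compound 1 and compound 3 lie within the usual scatter of each other, while compound 2 stands apart from both by more than the scatter.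

Compound 4 `CC(C)(C)/N=c1\c(O)c(O)\c1=N/Cc1ccc(F)cc1Cl` has not been measured. It stands to compound 1 as compound 3 stands to compound 2: hydrogen in place of methyl on a saturated chain carbon, two bonds along the chain from a double-bonded nitrogen. The place of the change reads the same word for word in both pairs, so this is the same change, made twice among the compounds here.

The expectation for compound 4 rests on that single precedent. In this assay, for the measured compounds named here, the step from compound 1 to compound 4 is expected to be a 3.3-fold higher number from compound 1 to compound 4 (0.52 log units; beyond the scatter), set beside a 3.9-fold higher number from compound 2 to compound 3 (0.59 log units; beyond the scatter); the range is kept wide since only one pair supports the step of a 3.9-fold higher number from compound 2 to compound 3 (0.59 log units; beyond the scatter). Compound 4 is therefore estimated at 5000 nM, with a range from 2000 nM to 15000 nM.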

Compound 4, half-maximal inhibitory concentration: 1400 nM
Estimate against measurement, compound 4: 3.6-fold (0.55 log units) above, outside the stated range (below it).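

On the core of compound 1, going from 1,1-dimethylpropyl to tert-butyl gives a 1.1-fold lower number from compound 1 to compound 4 (0.03 log units; within the scatter) in this assay, so the step seen on the core of compound 2 does not reappear and the two compounds of this pair cannot be told apart. The change therefore cannot be carried from one core to the other as a fixed step, since the outcome in these two pairs differs with the core that bears it: the same change on two cores in this assay, a 3.9-fold higher number (0.59 log units; beyond the scatter) from compound 2 to compound 3 and a 1.1-fold lower number (0.03 log units; within the scatter) from compound 1 to compound 4, 4.2-fold (0.62 log units) apart, beyond the scatter of two such steps This shows only that the result of removing this methyl depends on the core in these two pairs; it does not show which part of the difference between the cores matters, nor which of the two pairs is the more typical of the series, as each result rests on a single pair.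

Still open, as far as these compounds go, is whether a longer chain in place of the 1,1-dimethylpropyl group would respond to the core in the same way. Also open, from the compounds shown here alone, is which of the two pairs a core carrying a methoxy group or an amine would follow when the same methyl is removed.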